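This account rests on a few compounds, and the source may have more. Where it says the series, first, only, none or still open, it means among the compounds named here.

Series notes. In a functional assay on HCT-116 cells (Homo sapiens) for antiproliferative activity (a higher number here means a weaker inhibitor, a lower number a stronger inhibitor), compound 2 `CCS(=O)(=O)Nc1cccc(Oc2cc(F)c(F)c(Nc3ccc(I)cc3F)c2C(N)=O)c1` gives 65 nM, the lowest of the two numbers in hand. Compound 1 `NC(=O)c1c(Nc2ccc(I)cc2F)cc(F)cc1Oc1cccc(NS(N)(=O)=O)c1Cl` gives 87 nM in this assay, within the scatter of compound 2, so no order between the two is claimed. The unmeasured compound 3 `CN(C)S(=O)(=O)Nc1cccc(Oc2cc(F)c(F)c(Nc3ccc(I)cc3F)c2C(N)=O)c1` differs from compound 2 in one place: dimethylamino in place of ethyl on a sulfonyl sulfur. Within the data shown here, no step between measured compounds is in hand to calibrate this change. The expected step from compound 2 to compound 3 in this assay is a 1.2-fold higher number from compound 2 to compound 3 (0.06 log units; within the scatter), small and not beyond the scatter. Compound 3 is therefore estimated at 75 nM in this assay, with a range from 30 nM to 190 nM.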

Compound 3, half-maximal inhibitory concentration: 42 nM
For compound 3 the middle estimate is 1.8-fold (0.25 log units) above the measured one; the range from low to high includes it.
By their numbers in this assay, from the lowest: compounds 3, 2 and 1 (each within the scatter of the next, the first and the last beyond it).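

In this assay, among these compounds, the change from ethylsulfonyl to dimethylsulfamoyl gives a 1.5-fold lower number from compound 2 to compound 3 (0.19 log units; within the scatter) and is the first step that can be read at this position. On a sulfonyl sulfur whose other neighbour is the sulfonamide nitrogen, dimethylamino and ethyl therefore cannot be told apart in this assay. Nothing in hand explains this result. Still open, from the compounds shown here alone, is whether a longer chain such as n-butyl, a ring amine such as morpholine, or a carboxylic acid on the same sulfur would move the number beyond the scatter.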